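The source may hold more compounds than are shown below. What is called first, only, known or untested is meant among the compounds shown, and "the series" means these compounds.

Within the data shown here, compound 1 `O=C(O)COC/C=C1\C[C@H]2C[C@@H](O)[C@H](/C=N/NC(=O)Nc3ccc(Cl)c(Cl)c3)[C@H]2C1` gives 180 nM in a functional assay on a cell-free system (plasma) for agonist activity at thromboxane A2 receptor (Homo sapiens) (a higher number here means a weaker inhibitor, a lower number a stronger inhibitor), the highest of the two numbers so far. Compound 2 `O=C(O)COC/C=C1/C[C@H]2C[C@@H](O)[C@H](/C=N/NC(=O)Nc3ccc(Cl)c(Cl)c3)[C@H]2C1` gives 60 nM in this assay. The step of a 3.0-fold lower number from compound 1 to compound 2 (0.48 log units; beyond the scatter) rests only on (the fact that compounds 1 and 2 differ only in the configuration as drawn). Compound 3 `O=C(O)COC/C=C1\C[C@H]2C[C@@H](O)[C@H](/C=N/NC(=O)Nc3ccc([N+](=O)[O-])cc3)[C@H]2C1` differs from compound 1 by 4-nitrophenyl in place of 3,4-dichlorophenyl on an amide-type nitrogen. Among the measured compounds shown here, no measured step touches the group on the amide-type nitrogen, so the one step known gives no direction for this change, and it is expected to stay near compound 1 or to be a modest step either way. The estimated step is a 1.7-fold higher number from compound 1 to compound 3 (0.22 log units; within the scatter). In this assay compound 3 is estimated at 300 nM, within 70 nM to 1300 nM.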

Compound 3, half-maximal inhibitory concentration: 190 nM
Compound 3: the middle estimate sits 1.6-fold (0.20 log units) above what was measured; the range from low to high includes it.
By their numbers in this assay, from the lowest: compound 2; then compounds 1 and 3 (each within the scatter of the next).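

On the amide-type nitrogen, 4-nitrophenyl in place of 3,4-dichlorophenyl leaves the number in this assay unchanged within the scatter (a 1.1-fold higher number from compound 1 to compound 3 (0.02 log units; within the scatter)). For this pair, the two chlorines and the nitro group are interchangeable on the aromatic ring, even though the entering group adds hydrogen-bond acceptors. No available evidence bears on why this change leaves the number in place.

Still open, as far as these compounds go, is whether an amine on the aromatic ring, or a plain alkyl chain replacing that ring, would be tolerated on this nitrogen. Also open, from the compounds shown here alone, is whether 4-nitrophenyl would behave alike with the double bond drawn as in compound 2.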